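This account rests on a few compounds, and the source may have more. Where it says the series, first, only, none or still open, it means among the compounds named here.

Compound 1, `CCC(C)(C)Cc1c[nH]c(CCc2ccc(-c3cnccn3)cc2)n1`: 107 nM in a functional assay on HEK293 cells for agonist activity at Bombesin receptor subtype-3 (Mus musculus), read by luminescence and calcium flux, with a stated time of 10 min; on this read-out higher numbers stand for an effect only at larger amounts of compound and lower numbers for an effect already at smaller amounts
Compound 2, `CCC(C)(C)Cc1c[nH]c(CCc2ccc(-c3ccc(F)cn3)cc2)n1`: 105 nM in this assay

Going by the values given here, compound 2 stands at the lowest of the two numbers so far, but the gap to compound 1 is small: the step of a 1.0-fold lower number from compound 1 to compound 2 (0.01 log units; within the scatter) lies within the scatter, so the two compounds cannot be placed in order. Compound 3, `CCC(C)(C)Cc1c[nH]c(CCc2ccc(-c3cccc(N)n3)cc2)n1`, is the next compound to be measured. It differs from compound 2 in one place: 6-aminopyridin-2-yl in place of 5-fluoropyridin-2-yl on an aromatic carbon. Among the compounds with values here, only one measured step bears on the change at this position, the exchange from compound 1 to compound 2, and that step stayed within the scatter. Within the data shown here, no measured step shows the effect of an amino group on this ring, so the expectation rests on a single uninformative precedent. The step of a 1.1-fold higher number from compound 2 to compound 3 (0.06 log units; within the scatter) is therefore expected to be small, with no change beyond the scatter. For compound 3 the estimated value in this assay is 120 nM, with a range from 40 nM to 400 nM.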

Compound 3, half-maximal effective concentration: 119 nM
Compound 3: middle estimate off by 1.0-fold (0.00 log units), on the high side, and the stated range covers the measured number.
By their numbers in this assay, from the lowest: compounds 2, 1 and 3 (each within the scatter of the next).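

In this assay, the step of a 1.1-fold higher number from compound 2 to compound 3 (0.05 log units; within the scatter) and the step of a 1.1-fold higher number from compound 1 to compound 3 (0.05 log units; within the scatter) both stay within the scatter. The earlier pair had shown only that pyrazin-2-yl and 5-fluoropyridin-2-yl could not be told apart at this place, para to a large group; compound 3 extends this to 6-aminopyridin-2-yl, which adds a hydrogen-bond donor that neither of the other two groups carries, and the three compounds still cannot be placed in order. Nothing available explains why these groups read alike.

Going by these compounds, whether a plain phenyl ring, a piperidine or a carboxylic acid at this place would also stay within the scatter remains open. All three groups shown are six-membered aromatic rings, so the compounds leave untested how far this place accepts anything else.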